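A Methoxy Added to a Weak Sulfonamide Series

The source may hold more compounds than are shown below. What is called first, only, known or untested is meant among the compounds shown, and "the series" means these compounds.

Compound 1 `O=C1COc2ccc(-c3cnc(Cl)c(NS(=O)(=O)c4ccc(F)cc4)c3)cc2N1c1ccccc1` was tested in a functional assay on MCF7 cells (Homo sapiens) for antiproliferative activity, read by MTT assay, with a stated time of 72 h; a lower number here means a stronger inhibitor, a higher number a weaker inhibitor. In that assay compound 1 reaches only the assay limit, > 40000 nM, a limit rather than a measured number. Two relatives on the same core were also run. Compound 2 `CC(C)N1C(=O)COc2ccc(-c3cccc(NS(=O)(=O)c4ccc(F)cc4)c3)cc21` gives 26000 nM in this assay, and compound 3 `COc1ncc(-c2ccc3c(c2)N(C2CC2)C(=O)CO3)cc1NS(=O)(=O)c1ccc(F)cc1` gives 35200 nM. All three therefore sit at the weak end, with compound 1 standing at the limit itself (the limit of > 40000 nM in this assay, at which 1 of the 3 values shown sits). Compound 4 `COc1ccc(N2C(=O)COc3ccc(-c4cnc(Cl)c(NS(=O)(=O)c5ccc(F)cc5)c4)cc32)cc1` differs from compound 1 by methoxy in place of hydrogen on an aromatic carbon. Given how compounds 2 and 3 behave, no step beyond the usual scatter is expected in this assay, and a limit is again likely. Compound 4 is expected at 40000 nM, between 15000 nM and 100000 nM. The expected step is a number no higher from compound 1 to compound 4 (the limit leaves the size open).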

Compound 4, half-maximal inhibitory concentration: 36000 nM
For compound 4 the middle estimate is 1.1-fold (0.05 log units) above the measured one, within the range that was stated.
By their numbers in this assay, from the lowest: compounds 2, 3 and 4 (each within the scatter of the next). At a limit, above all of these: compound 1.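

Methoxy in place of hydrogen, para to a large group, gives an at least 1.1-fold lower number from compound 1 to compound 4 (0.04 log units; that floor lies within the scatter) in this assay. Compound 4 therefore gives this phenyl series a measured number with the 4-methoxyphenyl group, but it remains at the weak end. From the compounds shown here alone, the true size of the step stays unknown because compound 1 has only a limit: the limit of > 40000 nM in this assay, at which 1 of the 4 values shown sits.

Going by these compounds, whether an amine, a carboxylic acid or a longer chain at this place would move the number beyond the scatter remains open.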